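Extending the methoxy pattern on the pendant aryl ring

A few compounds are considered here, and "the series" means these few. Any claim that something is new, unique, unknown or untested is made for them only; others in the source may bear on it.

Measured compounds, with their values in a functional assay on HeLa cells (Homo sapiens) for cytotoxicity, read by MTT assay, with a stated time of 48 h; on this read-out lower numbers stand for stronger inhibition and higher numbers for weaker inhibition:
- compound 1 `Cc1cc2nc(NC(=O)c3cc(-c4ccc(F)cc4)n4nc(-c5ccccc5)cc4n3)sc2cc1C`: 18200 nM
- compound 2 `COc1ccc(-c2cc(C(=O)Nc3nc4cc(C)c(C)cc4s3)nc3cc(-c4ccccc4)nn23)cc1OC`: 6760 nM

Within the data shown here, compound 2 stands at the lowest of the two numbers in this assay; its nearest neighbour is compound 1, and the two differ by the step of a 2.7-fold lower number from compound 1 to compound 2 (0.43 log units; beyond the scatter), where the only change is 3,4-dimethoxyphenyl in place of 4-fluorophenyl on an aromatic carbon.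

Compound 3 `COc1cc(-c2cc(C(=O)Nc3nc4cc(C)c(C)cc4s3)nc3cc(-c4ccccc4)nn23)cc(OC)c1OC` has not yet been measured. It differs from compound 2 by methoxy in place of hydrogen on an aromatic carbon; cut one bond further out, the change reads 3,4-dimethoxyphenyl to 3,4,5-trimethoxyphenyl. Among the measured compounds shown here, only one measured step bears on this position, the one from compound 1 to compound 2, which was modest and went towards a lower number. It does not involve a methoxy entering in place of hydrogen, so it is an indirect guide. A further small lowering or no step beyond the scatter seems the most plausible expectation, so compound 3 is estimated at 5000 nM, with a range from 2000 nM to 15000 nM, meaning an expected step of a 1.4-fold lower number from compound 2 to compound 3 (0.13 log units; within the scatter).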

Compound 3, half-maximal inhibitory concentration: 8910 nM
For compound 3 the middle estimate is 1.8-fold (0.25 log units) below the measured one, within the range that was stated.
By their numbers in this assay, from the lowest: compounds 2 and 3 (each within the scatter of the next); then compound 1.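

In this assay, the step of a 1.3-fold higher number from compound 2 to compound 3 (0.12 log units; within the scatter) shows that a methoxy in place of hydrogen at this place on the ring, ortho to one methoxy group and meta to another, does not separate the two compounds, so the 3,4,5-trimethoxyphenyl ring and the 3,4-dimethoxyphenyl ring cannot be told apart here. The earlier pair showed only that the 3,4-dimethoxyphenyl ring reads lower than 4-fluorophenyl, while the step of a 2.0-fold lower number from compound 1 to compound 3 (0.31 log units; beyond the scatter) shows that the 3,4,5-trimethoxyphenyl ring also stays beyond the scatter on the same side of compound 1, though the step is modest. Among these three compounds, then, the gain over 4-fluorophenyl survives the added methoxy without growing, and none of them goes against this; no measurement at hand accounts for these numbers.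

The compounds shown leave open whether this tolerance belongs to methoxy alone or extends to other groups at the same place, such as a hydroxyl, an amine or a longer chain like ethoxy. They also leave open whether a ring carrying a single methoxy would read like compound 2 and compound 3 or like compound 1.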